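A few compounds are considered here, and "the series" means these few. Any claim that something is new, unique, unknown or untested is made for them only; others in the source may bear on it.

In a functional assay on DU-145 cells (Homo sapiens) for inhibition, read by trypan blue exclusion, with a stated time of 96 h (a lower number here means a stronger inhibitor of growth, a higher number a weaker inhibitor of growth), compound 1 `O=C(/C(=C\c1ccc(Cl)cc1)S(=O)(=O)c1ccc(Br)cc1)c1ccc(Br)cc1` gives 50000 nM. Its nearest neighbour among the measured compounds is compound 3 `O=C(/C(=C\c1ccc(OC(F)(F)F)cc1)S(=O)(=O)c1ccc(Br)cc1)c1ccc(Br)cc1`, which in this assay gives 25000 nM; the step from a 2.0-fold lower number from compound 1 to compound 3 (0.30 log units; within the scatter) shows that swapping one para-group on the aryl bound to the double-bonded chain carbon for another leaves the number essentially where it was. Among the measured compounds shown here, compound 2 `O=C(/C(=C\c1ccc(O)cc1O)S(=O)(=O)c1ccccc1Br)c1ccc(Br)cc1` reaches only the limit of the assay, (the limit of > 100000 nM in this assay, at which 1 of the 3 values shown sits), and in this assay compound 2 gives > 100000 nM; it differs from compound 1 in more than one place, so no single step can be drawn from it.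

Compound 4 `O=C(/C(=C\c1ccc(F)cc1F)S(=O)(=O)c1ccc(Br)cc1)c1ccc(Br)cc1` differs from compound 1 by 2,4-difluorophenyl in place of 4-chlorophenyl on a double-bonded chain carbon bound to a double-bonded chain carbon. For the measured compounds named here, the one comparable step, that from a 2.0-fold lower number from compound 1 to compound 3 (0.30 log units; within the scatter), lay within the scatter, so the expected change for compound 4 in this assay is none beyond the scatter, with some chance that the weaker end, as seen for compound 2, is reached. Compound 4 is therefore expected to give about 50000 nM, in the range 20000 nM to 120000 nM, a step of no change at the digits printed from compound 1 to compound 4 (within the scatter) from compound 1.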

Compound 4, concentration for 50% growth inhibition: 7500 nM
Compound 4: the middle estimate sits 6.7-fold (0.82 log units) above what was measured; the measured number lies below the stated range.
By their numbers in this assay, from the lowest: compound 4; then compounds 3 and 1 (each within the scatter of the next). At a limit, above all of these: compound 2.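

In this assay, among the compounds shown here, the change to 2,4-difluorophenyl is the first at this place that goes beyond the scatter: a 6.7-fold lower number from compound 1 to compound 4 (0.82 log units; beyond the scatter). The earlier step, a 2.0-fold lower number from compound 1 to compound 3 (0.30 log units; within the scatter), had stayed within the scatter, so the number at this place does respond to the aryl group it carries, although the response is modest and rests on a single compound. Nothing measured here bears on why this aryl group lowers the number.

The change removes the chloro and brings in two fluoro groups at once, so the compounds shown cannot tell whether the step follows the loss of chloro or the entry of either fluoro. As far as these compounds go, whether an amine or a carboxylic acid on this aryl ring would move the number further in either direction remains open.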